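The compounds below may be only part of what the source reports. "The series", "measured", "known", "first", "only" and "open" are said of these compounds alone.

In an assay on isolated protein for inhibition of Ca2+/calmodulin-dependent protein kinase II (CaM kinase II) (Rattus norvegicus), tested at 30 uM (on this read-out higher numbers stand for more inhibition at the one concentration tested (going by the name of the read-out) and lower numbers for less inhibition), two compounds have been measured so far. Compound 1, with the structure `Cn1cnc2c(Sc3ccc(F)cc3)ncnc21`, gives 5% in this assay. Compound 2, with the structure `c1ccc(C[n+]2c[nH]c3ncncc32)cc1`, gives 7% in this assay. The two numbers lie within the scatter of each other, so compound 2 stands together with compound 1 at a low level of inhibition, and nothing separates them beyond the noise of repeated measurement. Going by the values given here, no step between measured compounds with a single structural difference is available, so there is no measured precedent for the change that leads on to compound 3.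

Compound 3, with the structure `Fc1ccc(C[n+]2c[nH]c3ncncc32)cc1`, differs from compound 2 by fluoro in place of hydrogen on an aromatic carbon. Among the compounds with values here, because compound 2 gives 7% and no measured step shows what a change of this kind does here, the step from compound 2 to compound 3 is expected to stay within the scatter, in either direction, as a number 1 percentage points higher from compound 2 to compound 3 (within the scatter). Compound 3 is therefore estimated to give 8% in this assay, with a range from 0% to 18%.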

Compound 3, a percentage reported as inhibition, at one concentration (the size of the read-out at that concentration, not a potency): 5%
Estimate against measurement, compound 3: 3 percentage points above; the range from low to high includes it.
By their numbers in this assay, from the lowest: compounds 1, 3 and 2 (each within the scatter of the next).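

In this assay, going by these compounds alone, the first single-change step concerns fluoro in place of hydrogen on an aromatic carbon, para to a large group, and it reads a number 2 percentage points lower from compound 2 to compound 3 (within the scatter), so at this position this change does not separate the two compounds. Fluoro at this place on the six-membered aromatic ring of carbon only therefore leaves both compound 2 and compound 3 at a low level of inhibition at the one concentration tested. No supporting data bear on the reason for this result.

The compounds shown leave open whether a methoxy group, an amine or a carboxylic acid on that same aromatic carbon would move the read-out beyond the scatter, and whether fluoro on another carbon of the ring would behave as it does here. They also leave open whether a longer chain linking the aromatic ring to the shared core would change the picture in this assay at all, and a single step within the scatter cannot establish a trend for this series.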